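The source may report more compounds than this note shows. Statements on the series, on what has been measured and on what is new or still open speak of the compounds shown alone.

The measured compounds and their values:

compound 1 `C=C[C@H](/C=C\c1ccc(O)cc1)c1ccc(O)cc1`: > 100000 nM
compound 2 `Cc1c(O)cc2c(c1O)C(=O)/C(=C/c1ccc(O)cc1)CO2`: > 100000 nM
compound 3 `COc1cc(O)ccc1C(=O)/C=C/c1ccc(O)cc1`: 41800 nM

All three were tested in a functional assay on 3T3-L1 cells (Mus musculus) for inhibition, with a stated time of 7 days; a higher number here means a weaker inhibitor, a lower number a stronger inhibitor. For compound 1 the value > 100000 nM is a limit of the assay and not a number. For compound 2 the value > 100000 nM is likewise a limit. Compound 3 alone gives a number, 41800 nM. Compound 1 therefore stands at the limit of > 100000 nM in this assay, at which 2 of the 3 values shown sit, and on these numbers nothing separates it from compound 2, while compound 3 is the only one with a measured half-maximal inhibitory concentration.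

Compound 4 `C=C[C@H](/C=C\c1ccc(OC)cc1)c1ccc(O)cc1` has not yet been measured. It differs from compound 1 by methyl in place of hydrogen on an oxygen on an aromatic ring. Going by the values given here, no step between two measured compounds is at hand, so the size of this change cannot be read from the data. Given that compound 1 sits at the limit of > 100000 nM in this assay, at which 2 of the 3 values shown sit, compound 4 is expected to show a step of a number no higher from compound 1 to compound 4 (the limit leaves the size open) that is none beyond the scatter. Compound 4 is estimated at about 100000 nM, between 30000 nM and 300000 nM, most likely reported again as a limit.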

Compound 4, half-maximal inhibitory concentration: 45900 nM
Estimate against measurement, compound 4: 2.2-fold (0.34 log units) above; the measured number falls inside the stated range.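

Going by these compounds alone, the change from hydroxy to methoxy at this oxygen on an aromatic ring gives the first step that can be read in this set: in this assay it is an at least 2.1-fold lower number from compound 1 to compound 4 (0.33 log units; beyond the scatter). For compound 1 the value > 100000 nM is a limit of the assay and not a number. The step therefore fixes only the least size of the change, and its true size stays unknown, since compound 1 sits at that limit: the limit of > 100000 nM in this assay, at which 2 of the 4 values shown sit.

From the compounds shown here alone, what a longer chain on this oxygen, or an amine in place of the hydroxy, would do remains open. So does whether methyl on the other hydroxy of compound 1 would give a step of like size, or whether methyl on both would go further.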